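The source may report more compounds than this note shows. Statements on the series, on what has been measured and on what is new or still open speak of the compounds shown alone.

Measured compounds in a functional assay on CCRF-CEM cells (Homo sapiens); on this read-out lower numbers stand for higher toxicity in this test and higher numbers for lower toxicity in this test:
compound 1 `Cc1cn([C@@H]2O[C@H](CO[Si](C)(C)C(C)(C)C)[C@@]3(OS(=O)(=O)C=C3NCC(=O)C(=O)N3CCC3)[C@H]2O[Si](C)(C)C(C)(C)C)c(=O)n(C)c1=O` gives 21600 nM
compound 2 `Cc1cn([C@@H]2O[C@@H]3COC(=O)[C@]3(OS(C)(=O)=O)[C@H]2O)c(=O)[nH]c1=O` gives 160000 nM
compound 3 `COC(=O)NC1=CS(=O)(=O)O[C@@]12[C@@H](CO[Si](C)(C)C(C)(C)C)O[C@@H](n1cc(C)c(=O)n(C)c1=O)[C@@H]2O[Si](C)(C)C(C)(C)C` gives 30700 nM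

Compound 3 holds the second highest of the three numbers: compound 1 sits nearest, within the scatter, and compound 2 lies furthest, beyond it.

Compound 4 `CCNC(=O)NC1=CS(=O)(=O)O[C@@]12[C@@H](CO[Si](C)(C)C(C)(C)C)O[C@@H](n1cc(C)c(=O)n(C)c1=O)[C@@H]2O[Si](C)(C)C(C)(C)C` differs from compound 3 by ethylamino in place of methoxy on a carbonyl carbon. Going by the values given here, the only measured step that touches the same part of the core is a 1.4-fold higher number from compound 1 to compound 3 (0.15 log units; within the scatter), a swap on the amine nitrogen that stayed within the scatter. On that single precedent, the present change on the carbonyl carbon is expected to give a step of a 1.0-fold lower number from compound 3 to compound 4 (0.01 log units; within the scatter), with no direction beyond the scatter. Compound 4 is therefore estimated at 30000 nM, in a range from 12000 nM to 75000 nM.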

Compound 4, half-maximal cytotoxic concentration: 4260 nM
Compound 4: the middle estimate sits 7.0-fold (0.85 log units) above what was measured; the whole stated range lies above it.
By their numbers in this assay, from the lowest: compound 4; then compounds 1 and 3 (each within the scatter of the next); then compound 2.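

Ethylamino in place of methoxy on a carbonyl carbon gives a 7.2-fold lower number from compound 3 to compound 4 (0.86 log units; beyond the scatter) in this assay, so this site responds beyond the scatter, which the earlier step among the side-chain variants, compound 1 to compound 3, did not show. Ethylcarbamoyl in place of (((azetidin-1-yl)carbonyl)carbonyl)methyl on an amine nitrogen gives a 5.1-fold lower number from compound 1 to compound 4 (0.71 log units; beyond the scatter), so compound 4 also separates from the other variant. Nothing measured here accounts for either step.

Still open, going by these compounds, is whether the nitrogen or the ethyl chain of ethylamino carries the step. Ethoxy or a plain amino group on that carbonyl carbon would separate the two.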